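The compounds below may be only part of what the source reports. "The series", "measured", "known", "first", "only" and "open" are said of these compounds alone.

Compound 1 `O=C(CSc1snnc1-c1ccc(Br)cc1Br)Nc1ccccn1` carries pyridin-2-yl on the amide-type nitrogen, and in an ADME assay on MT4 cells (Homo sapiens) for cytotoxicity, read by MTT assay, with a stated time of 5 days (on this read-out higher numbers stand for lower toxicity in this test and lower numbers for higher toxicity in this test), compound 1 gives 42400 nM. Compound 2 `Cc1cccc(C)c1NC(=O)CSc1snnc1-c1ccc(Br)cc1Br` places 2,6-dimethylphenyl there; in this assay compound 2 reaches only a limit, >= 198000 nM. Compound 3 `O=C(CSc1snnc1-c1ccc(Br)cc1Br)Nc1cccnc1Cl` bears 2-chloropyridin-3-yl on that nitrogen; in this assay compound 3 likewise gives only a limit, > 240000 nM. Both replacements of pyridin-2-yl raised the number: an at least 4.6-fold higher number from compound 1 to compound 2 (0.66 log units; beyond the scatter) and an at least 5.6-fold higher number from compound 1 to compound 3 (0.75 log units; beyond the scatter). The step between the two limits cannot be sized, as a step that the two limits leave unreadable from compound 2 to compound 3 shows. Compound 3 thus stands at a limit, as does compound 2, with compound 1 below both. Compound 4 `O=C(CSc1snnc1-c1ccc(Br)cc1Br)Nc1ccccc1Cl` differs from compound 3 by 2-chlorophenyl in place of 2-chloropyridin-3-yl on an amide-type nitrogen. Among the measured compounds shown here, no measured step swaps a ring with one hetero atom for a carbon-only ring while keeping the chlorine, but the two measured steps both moved beyond the scatter toward higher numbers, and compound 2, the only carbon-only ring measured, also sits at a limit. Compound 4 is therefore expected to show no step beyond the scatter, an at least 1.2-fold lower number from compound 3 to compound 4 (0.07 log units; that floor lies within the scatter). The value of compound 4 is estimated at 200000 nM, within 60000 nM to 300000 nM.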

Compound 4, half-maximal cytotoxic concentration: > 240000 nM
Compound 4: a limit, no number (the forecaster's own chance of this, stated with the estimate: 60%); middle value at least 1.2-fold (0.07 log units) from the limit.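

In this assay, removing the ring nitrogen from the chlorine-bearing ring leaves the result at a limit, so a ring nitrogen is not required at this amide-type nitrogen for a value clear of compound 1. The carbon-only 2-chlorophenyl ring of compound 4 gives an at least 5.6-fold higher number from compound 1 to compound 4 (0.75 log units; beyond the scatter). The steps from compound 2 and compound 3 to compound 4 cannot be read, and compound 4 shares its limit with compound 3: the limit of > 240000 nM in this assay, at which 2 of the 4 values shown sit.

Any order among compound 2, compound 3 and compound 4 stays open, as none of them has a number. Also open, from the compounds shown here alone, is whether the lower value of compound 1 goes with its ring nitrogen or with the absence of a chlorine or methyl group on the ring, which a plain unsubstituted phenyl group on this nitrogen could help to separate.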